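Series notes: amine swap on the nitro-bearing ring, cytotoxicity

This account rests on a few compounds, and the source may have more. Where it says the series, first, only, none or still open, it means among the compounds named here.

Measured so far:
Compound 1 `Cc1ccc(-c2nc3ccccc3s2)cc1NC(=O)c1cc([N+](=O)[O-])c(N2CCCCC2)cc1Cl`: > 25000 nM (a limit of the assay).
Compound 2 `O=C(Nc1nc2ccc(Cl)cc2s1)c1cc([N+](=O)[O-])ccc1Cl`: > 27000 nM (a limit of the assay).

Both values come from an ADME assay on HEK293 cells (Homo sapiens) for cytotoxicity, with a stated time of 72 h; on this read-out lower numbers stand for an effect already at smaller amounts and higher numbers for an effect only at larger amounts of compound. For compound 1 the result > 25000 nM is a limit and not a number (the limit of > 25000 nM in this assay, at which 1 of the 2 values shown sits). For compound 2 the result > 27000 nM is likewise a limit (the limit of > 27000 nM in this assay, at which 1 of the 2 values shown sits). Going by the values given here, compound 1 therefore stands at the limit of this assay; no number places it on a scale, and no step between measured compounds is available for comparison.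

Compound 3 `Cc1ccc(-c2nc3ccccc3s2)cc1NC(=O)c1cc([N+](=O)[O-])c(N(C)C)cc1Cl` has not been measured. It differs from compound 1 by dimethylamino in place of piperidin-1-yl on an aromatic carbon. Among the compounds with values here, with no measured step to draw on, no shift beyond the usual scatter is expected in this assay; the step that the limit leaves unreadable from compound 1 to compound 3 is the expectation. Compound 3 is estimated at 30000 nM, with a range from 10000 nM to 100000 nM, and most likely again reported only as a limit.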

Compound 3, half-maximal effective concentration: > 25000 nM
Compound 3 gave a limit, no number (the forecaster's own chance of this, stated with the estimate: 75%); the middle value does not contradict the limit.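

Compound 1 and compound 3 both give only a limit in this assay, and the step between them, dimethylamino in place of piperidin-1-yl, cannot be read. The compounds shown leave open at what concentration any of them would register a value in this assay, and whether that amine swap changes it.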